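From 4-chlorophenyl to 4-methoxyphenyl in the series

The compounds below may be only part of what the source reports. "The series", "measured", "known", "first", "only" and "open" are said of these compounds alone.

In a functional assay on HT-29 cells (Homo sapiens) for antiproliferative activity, read by MTT assay, with a stated time of 48 h (on this read-out lower numbers stand for stronger inhibition and higher numbers for weaker inhibition), compound 1 (`Cc1ccc2nc(-c3ccc(F)cc3)cc(C(=O)OCc3ccccc3)c2c1`) gives 15100 nM, compound 2 (`COc1ccc(-c2cc(C(=O)OCc3ccccc3)c3cc(Cl)c(Cl)cc3n2)cc1`) gives 42200 nM and compound 3 (`Clc1ccc(-c2cc(COCc3ccccc3)c3cc(Cl)c(Cl)cc3n2)cc1`) gives 16800 nM. Compound 3 lies within the scatter of compound 1, while compound 2 gives a higher number, beyond the scatter.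

The next compound is compound 4 (`COc1ccc(-c2cc(COCc3ccccc3)c3cc(Cl)c(Cl)cc3n2)cc1`), with methoxy in place of chloro on an aromatic carbon, para to a large group: methoxy in place of chloro on an aromatic carbon. No measured pair in the series differs in this one place, so the size of the change is not shown directly. Among the compounds with values here, compound 2, the only measured compound with the 4-methoxyphenyl group, gives 42200 nM, but it also differs from compound 3 elsewhere. In this assay, a small move towards a higher number is therefore expected, probably not beyond the scatter. The expected change is a 1.5-fold higher number from compound 3 to compound 4 (0.19 log units; within the scatter). The estimate for compound 4 is 26000 nM, with an expected range of 11000 nM to 60000 nM.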

Compound 4, half-maximal inhibitory concentration: > 100000 nM
Compound 4 was reported as a limit (the forecaster's own chance of this, stated with the estimate: 5%); middle value at least 3.8-fold (0.58 log units) away from the limit.
By their numbers in this assay, from the lowest: compounds 1 and 3 (each within the scatter of the next); then compound 2. At a limit, above all of these: compound 4.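

In this assay compound 4 is reported only as a limit, not as a number: the limit of > 100000 nM in this assay, at which 1 of the 4 values shown sits. The change from 4-chlorophenyl to 4-methoxyphenyl can now be read in one place, with the (benzyloxy)methyl group held constant, and it gives an at least 5.9-fold higher number from compound 3 to compound 4 (0.77 log units; beyond the scatter); the limit leaves the full size of this step unknown. With 4-methoxyphenyl held constant, (benzyloxy)methyl in place of benzyloxycarbonyl gives an at least 2.3-fold higher number from compound 2 to compound 4 (0.37 log units; beyond the scatter), so the result at this position also depends on the group elsewhere in the molecule.

As far as these compounds go, whether the step belongs to methoxy itself or would follow other replacements of chloro, such as hydroxyl or an amine, remains open. From the compounds shown here alone, the effect of 4-chlorophenyl alongside benzyloxycarbonyl on the same core is also open.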